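This account rests on a few compounds, and the source may have more. Where it says the series, first, only, none or still open, it means among the compounds named here.

Compound 2 `C=C1C[C@]23C[C@@]1(O)CC[C@H]2c1ccc(OS(=O)(=O)c2ccc(C)cc2)c(C)c1[C@@H]3Cn1cc(-c2ccc(OC)cc2)nn1` and compound 1 `C=C1C[C@]23C[C@@]1(O)CC[C@H]2c1ccc(OS(=O)(=O)c2ccc(C)cc2)c(C)c1[C@@H]3Cn1cc(-c2ccc(Br)cc2)nn1` share one core and differ by bromo in place of methoxy on an aromatic carbon. In a functional assay on A549 cells (Homo sapiens) for cytotoxicity, read by MTT assay, with a stated time of 4 days (on this read-out lower numbers stand for stronger inhibition and higher numbers for weaker inhibition), compound 2 gives > 20000 nM, a limit of the assay. In this assay compound 1 gives > 20000 nM, likewise a limit. The step that the two limits leave unreadable from compound 2 to compound 1 is therefore not readable, since (the limit of > 20000 nM in this assay, at which 3 of the 3 values shown sit). Compound 3 `COc1ccc(-c2cn(C[C@H]3c4c(ccc(OS(=O)(=O)c5ccc(C)cc5)c4C)[C@@H]4CC[C@@]5(C)C[C@]43CC5=O)nn2)cc1` rests on a second core, and the difference between the two cores is not broken down here. In this assay compound 3 gives > 20000 nM, again a limit. Compound 4 `Cc1ccc(S(=O)(=O)Oc2ccc3c(c2C)[C@H](Cn2cc(-c4ccc(Br)cc4)nn2)[C@@]24CC(=O)[C@@](C)(CC[C@@H]32)C4)cc1` carries the same change on the core of compound 3, namely (bromo in place of methoxy on an aromatic carbon). Among the compounds with values here, because of the limit of > 20000 nM in this assay, at which 3 of the 3 values shown sit, no step has been read, and the expected step that the limit leaves unreadable from compound 3 to compound 4 is set close to nothing. Compound 4 is expected to give 35000 nM in this assay, between 15000 nM and 150000 nM, most probably reported once more only as a limit.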

Compound 4, half-maximal inhibitory concentration: > 20000 nM
Compound 4: only a limit was reported; the forecaster's own chance of this, stated with the estimate: 85%; the middle value lies beyond the limit too.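

In this assay, within the data shown here, compound 4 gives > 20000 nM, a limit, and compound 3 sits at a limit too, so no step between compound 3 and compound 4 can be read: the limit of > 20000 nM in this assay, at which 4 of the 4 values shown sit. The compounds shown leave open whether bromo in place of methoxy changes cytotoxicity on either core.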